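Pyrimidin-4-yl for phenyl on the amide of a thienopyridine

A few compounds are considered here, and "the series" means these few. Any claim that something is new, unique, unknown or untested is made for them only; others in the source may bear on it.

Of the compounds shown here, two sharing one core have been measured in a functional assay on MKN-74 cells (Homo sapiens) for antiproliferative activity, with a stated time of 24 h; on this read-out lower numbers stand for stronger inhibition and higher numbers for weaker inhibition. Compound 1 `CSc1ccccc1NC(=S)N1CCc2c(sc(NC(=O)c3ccccc3Cl)c2C(N)=O)C1` gives 13800 nM in this assay. Compound 2 `NC(=O)c1c(NC(=O)c2ccccc2)sc2c1CCN(C(=S)Nc1ccccc1Cl)C2` gives 11800 nM in this assay. The two numbers sit within the usual scatter of each other, so the data do not separate compound 2 from compound 1 in this assay.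

The next compound, compound 3 `NC(=O)c1c(NC(=O)c2ccncn2)sc2c1CCN(C(=S)Nc1ccccc1Cl)C2`, differs from compound 2 in one place: pyrimidin-4-yl in place of phenyl on a carbonyl carbon. Among the compounds with values here, no measured pair on this core shows the effect of such a change, so the account rests on the two values given and on the change itself, which keeps the ring size and the carbonyl attachment.

Within the data shown here, with no measured precedent, the step from compound 2 to compound 3 is expected to be small, a 1.3-fold higher number from compound 2 to compound 3 (0.10 log units; within the scatter), and most likely not beyond the scatter in this assay. Compound 3 is therefore estimated at 15000 nM in this assay, with a range from 6000 nM to 40000 nM.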

Compound 3, half-maximal inhibitory concentration: 28400 nM
Compound 3: the middle estimate sits 1.9-fold (0.28 log units) below what was measured, within the range that was stated.
By their numbers in this assay, from the lowest: compounds 2 and 1 (each within the scatter of the next); then compound 3.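

In this assay, within the data shown here, the amide carbonyl of the shared core does not tolerate every six-membered aromatic ring equally: pyrimidin-4-yl in place of phenyl on that carbonyl carbon gives a 2.4-fold higher number from compound 2 to compound 3 (0.38 log units; beyond the scatter), the first step in this set to lie beyond the scatter. Phenyl and pyrimidin-4-yl each have 6 heavy atoms and one six-membered aromatic ring, so this modest weakening comes with an exchange of ring atoms, 2 nitrogen for carbon, and not with a change in ring size or attachment. Nothing available explains why this exchange weakens the antiproliferative read-out.

Going by these compounds, it remains open whether a single ring nitrogen, as in a pyridinyl group, would weaken the read-out as much as the pyrimidin-4-yl of compound 3, and what a saturated ring such as cyclohexyl or morpholine would do on the same carbonyl carbon. On these data alone, it is also open whether the step would hold alongside the other substituents of compound 1, which differs from compound 2 in more than one place and so offers no second reading of this change.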